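The compounds below may be only part of what the source reports. "The series", "measured", "known", "first", "only" and "open" are said of these compounds alone.

In a functional assay on NCI-H23 cells (Homo sapiens) for cytotoxicity, read by sulforhodamine B assay, with a stated time of 48 h, tested at 1 uM (a lower number here means a stronger effect, a higher number a weaker effect of the compound at the concentration tested), compound 1 `COc1cc(C)cc(-c2c(-c3ccnc(-c4ccc(C(C)=O)cc4)c3)cnn2CC#N)c1` gives 19%, while compound 2 `Cc1cc(O)cc(-c2nn(CC#N)cc2-c2ccnc(-c3ccc(Oc4ccccc4)cc3)c2)c1` gives -64%, the lowest of the two numbers recorded; compound 1 stands a long way higher, well beyond the usual scatter. Within the data shown here, no pair of compounds differing in only one place has been measured, so the weight of any single change on this assay remains unknown.

Compound 3 `Cc1cc(O)cc(-c2nn(CC#N)cc2-c2ccnc(-c3ccc(N(C)C)cc3)c2)c1` has not yet been measured. It differs from compound 2 in one place: dimethylamino in place of phenoxy on an aromatic carbon. Among the measured compounds shown here, since no measured step shows what such a swap does here, the expectation must stay loose. A step of a number 44 percentage points higher from compound 2 to compound 3 (beyond the scatter) is expected, upward toward weaker effect, but with a wide margin that also allows no change beyond the scatter. Compound 3 is estimated at -20%, within a range from -70% to 40%.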

Compound 3, a percentage reported as activity, at one concentration (the size of the read-out at that concentration, not a potency): 24%
The estimate for compound 3 lay 44 percentage points below the measured number, and the stated range covers the measured number.
By their numbers in this assay, from the lowest: compound 2; then compounds 1 and 3 (each within the scatter of the next).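

In this assay, replacing phenoxy with dimethylamino on an aromatic carbon, para to a large group, gives a number 88 percentage points higher from compound 2 to compound 3 (beyond the scatter), a large step toward weaker effect. Among these compounds, this is the first single-place comparison here, and it shows that the group at this position can strongly change the read-out, with phenoxy as the better of the two groups. The change removes a six-membered aromatic ring of carbon only and reduces the group from 7 heavy atoms to 3, but it also replaces oxygen with nitrogen as the attached atom, so this one step cannot separate those differences, and nothing on hand explains the step.

On these data alone, it remains open whether a methoxy group or an unsubstituted phenyl ring at this position would retain the effect of compound 2. As far as these compounds go, it is also open whether a benzyloxy group would do so.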